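Acetamido to Amino on Two Related Cores

The source may report more compounds than this note shows. Statements on the series, on what has been measured and on what is new or still open speak of the compounds shown alone.

Of the compounds shown here, three have been tested in an ADME assay on THP-1 cells (Homo sapiens) for cytotoxicity, read by flow cytometry and propidium iodide staining, with a stated time of 72 h (a higher number here means a weaker inhibitor, a lower number a stronger inhibitor), and a fourth awaits measurement. Compound 1 `CC(=O)Nc1ccc2oc(-c3ccccc3F)cc(=O)c2c1` carries an acetamido group on its core. In this assay compound 1 gives > 125000 nM, which is a limit of the assay rather than a number, as noted in the limit of > 125000 nM in this assay, at which 1 of the 3 values shown sits. Compound 2 `Nc1ccc2oc(-c3ccccc3F)cc(=O)c2c1` differs from compound 1 by a single change, (hydrogen in place of acetyl on a nitrogen on an aromatic ring), and in this assay compound 2 gives 44000 nM. That change produced an at least 2.8-fold lower number from compound 1 to compound 2 (0.45 log units; beyond the scatter), a step that can only be bounded from one side, since the starting point is a limit.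

Compound 3 `CC(=O)Nc1ccc2oc(-c3ccccc3)c(O)c(=O)c2c1` shares the acetamido group but sits on a different core; how the two cores differ is not broken down here. In this assay compound 3 gives 36000 nM, a value within the usual scatter of that of compound 2.

Compound 4 `Nc1ccc2oc(-c3ccccc3)c(O)c(=O)c2c1` is compound 3 with the same change, (hydrogen in place of acetyl on a nitrogen on an aromatic ring), at a place described in identical terms. The step from compound 3 to compound 4 is expected to be of at least modest size, resting on the measured step of an at least 2.8-fold lower number from compound 1 to compound 2 (0.45 log units; beyond the scatter), so the expected step is a 2.4-fold lower number from compound 3 to compound 4 (0.38 log units; beyond the scatter). Compound 4 is therefore expected to give about 15000 nM, plausibly between 5000 nM and 40000 nM.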

Compound 4, half-maximal inhibitory concentration: 27000 nM
The estimate for compound 4 lay 1.8-fold (0.26 log units) below the measured number, within the range that was stated.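

In this assay, within the data shown here, replacing the acetamido group of compound 3 with an amino group gave a 1.3-fold lower number from compound 3 to compound 4 (0.12 log units; within the scatter), so on this core the change produced no step that can be told apart from the ordinary spread of repeated measurements. The clear step seen on the core of compound 1 therefore did not show up as a clear step on the second core, but this does not prove that the change acts differently on the two cores: the same change on two cores in this assay, an at least 2.8-fold lower number (0.45 log units; beyond the scatter) from compound 1 to compound 2 and a 1.3-fold lower number (0.12 log units; within the scatter) from compound 3 to compound 4; the limit leaves it open whether they differ. Compound 1 stands at a limit of the assay and not at a number, which is why the size of the first step stays open on one side: the limit of > 125000 nM in this assay, at which 1 of the 4 values shown sits.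

Among these compounds, with only two matched pairs, no general rule about this change can be drawn for the series, and a firm value in place of the limit would be needed to compare the two steps directly. The compounds shown also leave open how this assay would respond if the nitrogen carried something other than acetyl or hydrogen, such as a methyl group or a longer chain like butanoyl.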